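Cytotoxicity at the Limit: Hydroxy Gives Way to Amino

The compounds below may be only part of what the source reports. "The series", "measured", "known", "first", "only" and "open" are said of these compounds alone.

Of the compounds shown here, three with a shared core have been tested: compound 1 `Nc1ncnc2c(CN3C[C@H](O)[C@H](O)[C@H]3CO)csc12`, compound 2 `O=c1[nH]cnc2c(CN3C[C@H](O)[C@H](O)[C@H]3CO)csc12` and compound 3 `OC[C@@H]1[C@@H](O)[C@@H](O)CN1Cc1c[nH]c2c(O)ncnc12`. The read-out is an ADME assay on MRC5 cells (Homo sapiens) for cytotoxicity, with a stated time of 48 h; on this read-out higher numbers stand for weaker inhibition and lower numbers for stronger inhibition. Compound 1 gives only a limit of the assay, > 64000 nM. Compound 2 likewise gives only a limit, > 64000 nM. Compound 3 also gives only a limit, > 64000 nM. Compound 3 therefore stands exactly where the other two stand, at the limit (the limit of > 64000 nM in this assay, at which 3 of the 3 values shown sit), with no number beneath it and no basis for ranking the three against one another.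

Compound 4 `Nc1ncnc2c(CN3C[C@H](O)[C@H](O)[C@H]3CO)c[nH]c12` is not yet measured. It differs from compound 3 in one place: amino in place of hydroxy on an aromatic carbon. Every measured compound sits at the limit (the limit of > 64000 nM in this assay, at which 3 of the 3 values shown sit), so in this assay the expected step for this change is none beyond the usual scatter. Compound 4 is expected to show 100000 nM, in a range from 64000 nM to 250000 nM, which is an expected step that the limit leaves unreadable from compound 3 to compound 4.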

Compound 4, half-maximal inhibitory concentration: > 64000 nM
Compound 4: only a limit was reported (the forecaster's own chance of this, stated with the estimate: 90%); the middle value does not contradict the limit.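

Within the data shown here, no step from compound 3 to compound 4 can be read, because both sit at a limit and not at a number: the limit of > 64000 nM in this assay, at which 4 of the 4 values shown sit. The compounds shown leave open whether any of them has a readable value in this assay and how amino and hydroxy would then compare.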